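Piperazine amide series: solubility on changing the acyl group

A few compounds are considered here, and "the series" means these few. Any claim that something is new, unique, unknown or untested is made for them only; others in the source may bear on it.

Compound 2 `CCC(C)C(=O)N1CCN(c2nc(=O)c3cc(C(F)(F)F)cc([N+](=O)[O-])c3s2)CC1` holds the higher of the two numbers in a physicochemical assay for solubility, read by HPLC; a higher number here means a more soluble compound, a lower number a less soluble compound: compound 2 gives 104 ug/mL, while compound 1 `CC(C)(C)C(=O)N1CCN(c2nc(=O)c3cc(C(F)(F)F)cc([N+](=O)[O-])c3s2)CC1` gives 5.87 ug/mL. Within the data shown here, the one measured step, an 18-fold higher number from compound 1 to compound 2 (1.25 log units; beyond the scatter), came with sec-butyl in place of tert-butyl on a carbonyl carbon. Compound 3 `O=C(C1CCC1)N1CCN(c2nc(=O)c3cc(C(F)(F)F)cc([N+](=O)[O-])c3s2)CC1` is not yet measured; it differs from compound 2 by cyclobutyl in place of sec-butyl on a carbonyl carbon. Among the measured compounds shown here, the measured step bears on it only in that both changes sit on the same carbonyl carbon and exchange one acyl group for another; no measured pair shows what a ring in that place does. With cyclobutyl in place of sec-butyl, a step of modest size is expected, more likely downward than upward, and it may stay within the scatter. For compound 3 the expected value in this assay is 50 ug/mL, with a range from 15 ug/mL to 150 ug/mL, corresponding to an expected step of a 2.1-fold lower number from compound 2 to compound 3 (0.32 log units; beyond the scatter).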

Compound 3, solubility: 39.3 ug/mL
For compound 3 the middle estimate is 1.3-fold (0.10 log units) above the measured one; the measured number falls inside the stated range.
By their numbers in this assay, from the lowest: compound 1; then compound 3; then compound 2.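

Closing the sec-butyl group into cyclobutyl leaves the count of carbon atoms unchanged, yet a 2.6-fold lower number from compound 2 to compound 3 (0.42 log units; beyond the scatter) is seen in this assay on this change at the carbonyl carbon, so the number here is not set by that count alone. Cyclobutyl in place of tert-butyl gives a 6.7-fold higher number from compound 1 to compound 3 (0.83 log units; beyond the scatter) in the same assay, which places the ring between the two open-chain groups, with tert-butyl lowest and sec-butyl highest of the three. The compounds shown offer no measurement that accounts for this order.

Still open, as far as these compounds go, is whether the ring itself or its size drives the position of compound 3, which cyclopropyl and cyclopentyl on the same carbonyl carbon would address. A straight butyl chain, or an acyl group carrying an amine or a hydroxyl, would show how far the order extends beyond these three hydrocarbon groups.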